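The source may report more compounds than this note shows. Statements on the series, on what has been measured and on what is new or still open speak of the compounds shown alone.

Compound 3, `C[C@H](c1ccc(-c2ccccc2-c2nc(=O)o[nH]2)cc1)N(CC1CC1)c1nc2c(C(=O)O)cccc2o1`, sits second highest among the three numbers in a functional assay on CAL1 cells for inhibition of chemerin-like receptor 1 (Homo sapiens), with a stated time of 45 min; a higher number here means a weaker inhibitor, a lower number a stronger inhibitor. Its nearest neighbour is compound 2, `CCCCN(c1nc2c(C(=O)O)cccc2o1)[C@H](C)c1ccc(-c2ccccc2-c2nnn[nH]2)cc1`, which in this assay gives 17 nM, a gap that lies within the scatter; the furthest is compound 1, `C[C@H](c1ccc(-c2cc(Cl)ccc2-c2nc(=O)o[nH]2)cc1)N(CC1CC1)c1nc2c(C(=O)O)cccc2o1`, which in this assay gives 1.3 nM, while compound 3 itself gives 11 nM. Among the compounds with values here, the one measured step that touches the ring in question is an 8.5-fold higher number from compound 1 to compound 3 (0.93 log units; beyond the scatter), a modest but real loss when the chloro is removed. Compound 4, `Cc1ccc(-c2nc(=O)o[nH]2)c(-c2ccc([C@@H](C)N(CC3CC3)c3nc4c(C(=O)O)cccc4o3)cc2)c1`, differs from compound 3 by methyl in place of hydrogen on an aromatic carbon, the single carbon entering on an aromatic carbon of that same ring. Since compound 1 shows that a small substituent there gives 1.3 nM, a methyl is expected to recover part of that gain, so a step of a 3.7-fold lower number from compound 3 to compound 4 (0.56 log units; beyond the scatter) toward a lower number is expected. Compound 4 is therefore estimated at 3 nM, with a range from 1.2 nM to 8 nM.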

Compound 4, half-maximal inhibitory concentration: 3.2 nM
Beside the measured number, compound 4's estimate is 1.1-fold (0.03 log units) below it; measured number inside the range.
By their numbers in this assay, from the lowest: compound 1; then compound 4; then compounds 3 and 2 (each within the scatter of the next).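

In this assay, a 3.4-fold lower number from compound 3 to compound 4 (0.54 log units; beyond the scatter) shows that the gain at this place on the ring is not confined to chloro: a single carbon also lowers the number beyond the scatter. The two substituents are still not equal, and a 2.5-fold higher number from compound 1 to compound 4 (0.39 log units; beyond the scatter) separates methyl from chloro, so the three compounds that differ only here run chloro, methyl, hydrogen from the lowest number to the highest. Nothing given on these compounds accounts for this order.

What the compounds shown leave open is whether a fluoro, an ethyl, a methoxy or an amine at this same place would match or pass chloro. Also open, as far as these compounds go, is whether the same order would hold with a butyl chain in place of the cyclopropylmethyl group.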